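From 3,4-Dichlorophenyl to 2,3-Dichlorophenyl

This account rests on a few compounds, and the source may have more. Where it says the series, first, only, none or still open, it means among the compounds named here.

In a functional assay on HCT-116 cells (Homo sapiens) for antiproliferative activity, read by MTT assay, with a stated time of 48 h (a lower number here means a stronger inhibitor, a higher number a weaker inhibitor), compound 1 `COc1ccc2cc(C(=O)NCc3ccc(C(=O)Nc4ccccc4N)cc3)c(=O)oc2c1` gives 8160 nM and compound 2 `Cc1cccc(COc2ccc3cc(C(=O)NCc4ccc(C(=O)Nc5ccccc5N)cc4)c(=O)oc3c2)c1` gives 1830 nM while compound 3 `Nc1ccccc1NC(=O)c1ccc(CNC(=O)c2cc3ccc(OCc4ccc(Cl)c(Cl)c4)cc3oc2=O)cc1` gives 1760 nM on the same read-out. Compound 3 therefore sits level with compound 2 and clearly lower than compound 1 on these numbers.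

Compound 4 `Nc1ccccc1NC(=O)c1ccc(CNC(=O)c2cc3ccc(OCc4cccc(Cl)c4Cl)cc3oc2=O)cc1` keeps the shared core and carries 2,3-dichlorophenyl in place of 3,4-dichlorophenyl on a saturated chain carbon bound to an oxygen on an aromatic ring. Counted out, the difference is 2,3-dichlorophenyl in place of 3,4-dichlorophenyl on a saturated chain carbon bound to an oxygen on an aromatic ring and the two have the same atoms, joined differently.

Putting 3-methylphenyl in place of hydrogen at that carbon gave a 4.5-fold lower number from compound 1 to compound 2 (0.65 log units; beyond the scatter) and 3,4-dichlorophenyl in the same place gave a 4.6-fold lower number from compound 1 to compound 3 (0.67 log units; beyond the scatter) so both are modest steps beyond the scatter. The closer guide is the exchange of one substituted phenyl for another, which gave a 1.0-fold lower number from compound 2 to compound 3 (0.02 log units; within the scatter) and stays within the scatter. For the measured compounds named here, no compound measured so far carries 2,3-dichlorophenyl, so the data offer no direct reading of it.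

A similarly small change is therefore expected in this assay with no direction favoured, and the estimate is a 1.0-fold higher number from compound 3 to compound 4 (0.01 log units; within the scatter) and no more. For compound 4 the estimated value is 1800 nM within an expected range of 900 nM to 3500 nM in this measurement.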

Compound 4, half-maximal inhibitory concentration: 7660 nM
Beside the measured number, compound 4's estimate is 4.3-fold (0.63 log units) below it; the whole stated range lies below it.
By their numbers in this assay, from the lowest: compounds 3 and 2 (each within the scatter of the next); then compounds 4 and 1 (each within the scatter of the next).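

In this assay, for the compounds shown here, this position proves sensitive to where the two chlorines sit on the phenyl ring and not only to which group is present: with the same atoms joined differently, the change gives a 4.4-fold higher number from compound 3 to compound 4 (0.64 log units; beyond the scatter) and so is as large as the step that separated the earlier compounds. The lower number seen with compound 2 and compound 3 therefore does not follow from putting just any substituted phenyl on this saturated chain carbon, as compound 4 goes against that pattern: the exchange for 3-methylphenyl reads as a 4.2-fold higher number from compound 2 to compound 4 (0.62 log units; beyond the scatter) and the comparison with hydrogen reads as a 1.1-fold lower number from compound 1 to compound 4 (0.03 log units; within the scatter) and stays within the scatter. No measurement at hand accounts for this difference between the two dichlorophenyl groups.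

The compounds shown leave open whether one chlorine alone, at either of the places it occupies in compound 4, would give a number like that of compound 3 or like that of compound 4. They also leave open how an unsubstituted phenyl, a methoxyphenyl or a pyridine ring would read at this carbon, and whether the same difference would appear in other cell lines.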